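The source may report more compounds than this note shows. Statements on the series, on what has been measured and on what is new or still open speak of the compounds shown alone.

For the measured compounds named here, in a functional assay on T47D cells (Homo sapiens) for inhibition, read by CCK-8 assay, with a stated time of 72 h, tested at 10 uM (a lower number here means less inhibition of growth, a higher number more inhibition of growth at the concentration tested), compound 1 `CN(C)C(=O)c1cc2cnc(Nc3ccc(NC(=O)C4(C(=O)Nc5ccccc5F)CC4)cc3)nc2n1C1CCCC1` gives 97.8% and compound 2 `Cc1ccc(NC(=O)C2(C(=O)Nc3ccc(Nc4ncc5cc(C(=O)N(C)C)n(C6CCCC6)c5n4)cc3)CC2)cc1` gives 99.6%, so compound 2 stands level with the only other measured compound. Compound 3 `CN(C)C(=O)c1cc2cnc(Nc3ccc(NC(=O)C4(C(=O)Nc5ccc(O)cc5)CC4)cc3)nc2n1C1CCCC1` has hydroxy in place of methyl on an aromatic carbon, para to a large group (hydroxy in place of methyl on an aromatic carbon). Going by the values given here, the one measured step bearing on this is a number 1.8 percentage points higher from compound 1 to compound 2 (within the scatter), a swap of 4-methylphenyl for 2-fluorophenyl on an amide-type nitrogen. Among the compounds with values here, no measured compound carries hydroxy, so the evidence is thin. The expected step is a number 7.6 percentage points lower from compound 2 to compound 3 (within the scatter), slightly downward and not expected to exceed the scatter. For compound 3 the estimated value is 92%, with an expected range of 72% to 100%.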

Compound 3, percent growth inhibition at one concentration: 95.8%
For compound 3 the middle estimate is 3.8 percentage points below the measured one, within the range that was stated.
By their numbers in this assay, from the lowest: compounds 3, 1 and 2 (each within the scatter of the next).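

In this assay, hydroxy in place of methyl on the aromatic carbon para to a large group gives a number 3.8 percentage points lower from compound 2 to compound 3 (within the scatter): this place accepts a hydrogen-bond donor and acceptor with no shift beyond the scatter. 4-Hydroxyphenyl in place of 2-fluorophenyl on the amide-type nitrogen gives a number 2 percentage points lower from compound 1 to compound 3 (within the scatter), so the three aryl groups stand level at this single concentration. Nothing measured on these compounds bears on this result.

Open, as far as these compounds go, is whether a carboxylic acid or an amine at this place stays level with hydroxy and methyl. Also open, from the compounds shown here alone, is whether a longer chain there does the same.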